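The source may hold more compounds than are shown below. What is called first, only, known or untested is meant among the compounds shown, and "the series" means these compounds.

Working notes on the series around the core of compound 1 `C=C(CC)C(=O)c1ccc(OCC(=O)Nc2cccc(C(=O)O)c2)c(Cl)c1Cl`. Among the compounds with values here, in a functional assay on CLL cells (Homo sapiens) for cytotoxicity, read by MTT assay, with a stated time of 48 h (a lower number here means that less compound is needed, a higher number that more compound is needed for the effect), compound 1 gives 20600 nM, and compound 2 `C=C(CC)C(=O)c1ccc(OCC(=O)Nc2ccc(O)c(Cl)c2)c(Cl)c1Cl` gives 5500 nM, the lower of the two numbers so far. Compound 3 `C=C(CC)C(=O)c1ccc(OCC(=O)Nc2ccc(C(C)=O)cc2)c(Cl)c1Cl` has not been measured. It carries 4-acetylphenyl in place of 3-chloro-4-hydroxyphenyl on an amide-type nitrogen. Within the data shown here, only one measured step bears on this position, a 3.7-fold lower number from compound 1 to compound 2 (0.57 log units; beyond the scatter), which also replaces one aryl group with another on that nitrogen. It gives a scale for such swaps, but it does not involve 4-acetylphenyl and does not settle the direction. In this assay a smaller step towards a higher number is therefore expected, possibly not beyond the scatter. The estimated step is a 1.6-fold higher number from compound 2 to compound 3 (0.21 log units; within the scatter). For compound 3 the expected value is 9000 nM, with an estimated range of 3500 nM to 22000 nM.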

Compound 3, half-maximal effective concentration: 3900 nM
Beside the measured number, compound 3's estimate is 2.3-fold (0.36 log units) above it; low and high end bracket the measured number.
By their numbers in this assay, from the lowest: compounds 3 and 2 (each within the scatter of the next); then compound 1.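

In this assay the step of a 1.4-fold lower number from compound 2 to compound 3 (0.15 log units; within the scatter) shows that 4-acetylphenyl and 3-chloro-4-hydroxyphenyl on the amide-type nitrogen are not separated here, although the entering group carries no chlorine and no hydrogen-bond donor. The step of a 5.3-fold lower number from compound 1 to compound 3 (0.72 log units; beyond the scatter) gives a second comparison beyond the scatter against 3-carboxyphenyl, so among these three compounds only compound 1 stands apart. Nothing available explains this separation or the lack of one between the other two compounds.

Still open, as far as these compounds go, is how an aryl group bearing an amine, or a longer chain in place of the acetyl group, would read in this assay on this nitrogen. Also open, from the compounds shown here alone, is whether a carboxylic acid elsewhere on the aryl ring gives the same result as 3-carboxyphenyl.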